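The source may report more compounds than this note shows. Statements on the series, on what has been measured and on what is new or still open speak of the compounds shown alone.

In a functional assay on MCF7 cells (Homo sapiens) for antiproliferative activity, read by MTT assay, with a stated time of 24 h (a lower number here means a stronger inhibitor, a higher number a weaker inhibitor), compound 1 `Brc1cccc(Cc2nnc(Cn3nnc4ccccc43)o2)c1` gives 269000 nM, and compound 2 `COc1cccc(Cc2nnc(Cn3nnc4ccccc43)o2)c1` gives 241000 nM. The change between them, (methoxy in place of bromo on an aromatic carbon), made a step of a 1.1-fold lower number from compound 1 to compound 2 (0.05 log units; within the scatter). Compound 3 `Brc1ccc(-c2nnc(Cn3nnc4ccccc43)o2)cc1` gives 387000 nM in this assay; how its core differs from that of compound 1 is not broken down here. Compound 4 `COc1ccc(-c2nnc(Cn3nnc4ccccc43)o2)cc1` carries the same kind of change against compound 3, (methoxy in place of bromo on an aromatic carbon), but the place differs: in compound 2 the methoxy sits meta to a large group, in compound 4 para to a large group. Because the step of a 1.1-fold lower number from compound 1 to compound 2 (0.05 log units; within the scatter) stayed within the scatter, the step from compound 3 to compound 4 is expected to be small as well, about a 1.1-fold lower number from compound 3 to compound 4 (0.04 log units; within the scatter). Compound 4 is therefore estimated at 350000 nM, between 190000 nM and 650000 nM.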

Compound 4, half-maximal inhibitory concentration: 376000 nM
For compound 4 the middle estimate is 1.1-fold (0.03 log units) below the measured one, and the stated range covers the measured number.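

In this assay the exchange of bromo for methoxy on the core of compound 3 again gives only a small step (a 1.0-fold lower number from compound 3 to compound 4 (0.01 log units; within the scatter)). Set beside the step on the core of compound 1, the change reads the same on both cores: the same change on two cores in this assay, a 1.1-fold lower number (0.05 log units; within the scatter) from compound 1 to compound 2 and a 1.0-fold lower number (0.01 log units; within the scatter) from compound 3 to compound 4, 1.1-fold (0.04 log units) apart, within the scatter of two such steps. This shows that the exchange leaves the number within the scatter on these two cores, but with no step beyond the scatter, it does not show a measurable effect that carries from one core to another, nor that other cores would behave alike.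

The compounds shown leave open whether an amine, a carboxylic acid or a longer chain in this place would shift the number beyond the scatter. They also leave open whether any such shift would hold across both cores.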